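The compounds below may be only part of what the source reports. "The series", "measured", "known", "first", "only" and "open" are said of these compounds alone.

Measured in a functional assay on SK-MEL-28 cells (Homo sapiens) for inhibition, read by sulforhodamine B assay, with a stated time of 48 h; on this read-out lower numbers stand for stronger inhibition of growth and higher numbers for weaker inhibition of growth:
compound 1, `COc1cc(-c2nn(-c3cccc(NC(=O)Nc4cc(C(F)(F)F)cc(C(F)(F)F)c4)c3)cc2-c2ccncc2)ccc1Cl` — 1700 nM
compound 2, `COc1cc(-c2nn(-c3cccc(NC(=O)c4cccc(C(F)(F)F)c4)c3)cc2-c2ccncc2)ccc1Cl` — a limit only, > 50000 nM

Compound 2 stands at the limit of this assay ; its entry is a limit of the read-out and not a number (the limit of > 50000 nM in this assay, at which 1 of the 2 values shown sits). The unmeasured compound 3, `COc1cc(-c2nn(-c3cccc(NC(=O)Nc4ccc(Cl)c(Cl)c4)c3)cc2-c2ccncc2)ccc1Cl`, differs from compound 2 in one place: (3,4-dichlorophenyl)amino in place of 3-(trifluoromethyl)phenyl on a carbonyl carbon. Through that change compound 3 carries the same carbamoyl link as compound 1, and the two then differ only in the outer aryl ring, bis(trifluoromethyl)phenyl against 3,4-dichlorophenyl. Among the measured compounds shown here, no step between measured compounds exists here, so the size of the change can be gauged only from where compound 1 stands against the limit of compound 2. The step of an at least 16-fold lower number from compound 2 to compound 3 (1.22 log units; beyond the scatter) is expected to be a gain in growth inhibition well beyond the scatter. For compound 3 the estimate is 3000 nM, with a range from 800 nM to 15000 nM, because compound 1 with the same carbamoyl link gives 1700 nM in this assay .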

Compound 3, concentration for total growth inhibition: 7320 nM
Estimate against measurement, compound 3: 2.4-fold (0.39 log units) below, and the stated range covers the measured number.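

In this assay, (3,4-dichlorophenyl)amino in place of 3-(trifluoromethyl)phenyl on a carbonyl carbon gives an at least 6.8-fold lower number from compound 2 to compound 3 (0.83 log units; beyond the scatter), so a readable growth inhibition appears at this position with a carbamoyl link and a ring other than the bis(trifluoromethyl)phenyl of compound 1. Compound 1 alone could not show that a measurable number with this link extends to a second outer ring; compound 3 now shows this with a chlorine-bearing ring, at 7320 nM. The step gives only a lower bound on the size of the change, because compound 2 has a limit of the read-out and not a number: the limit of > 50000 nM in this assay, at which 1 of the 3 values shown sits.

The change replaces the link and the outer ring together and adds the amide-type hydrogen, so the compounds shown cannot separate the share of the amino nitrogen from that of the ring substituents; (3,4-dichlorophenyl) directly on the carbonyl, or (3-(trifluoromethyl)phenyl)amino, would divide the two. Also open, going by these compounds, is whether an oxygen atom or a methylene in place of the amino nitrogen would keep a measurable number in this assay.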